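Swapping a Hydroxy Group for a Ketone-Bearing Chain

The source may hold more compounds than are shown below. What is called first, only, known or untested is meant among the compounds shown, and "the series" means these compounds.

Measured so far:
compound 1 `CCCCc1cn(-c2ccc(NC(=O)Nc3cc(O)ccc3C)cc2)nn1` — 490 nM
compound 2 `Cc1ccccc1NC(=O)Nc1ccc(-n2cc(CCCN3CCN(C)CC3)nn2)cc1` — 40100 nM
not yet measured:
compound 3 `CCCCc1cn(-c2ccc(NC(=O)Nc3cc(CCC(C)=O)ccc3C)cc2)nn1`

Of the compounds shown here, two have been tested in an assay on isolated protein for inhibition of ATP-dependent RNA helicase DDX3X (Homo sapiens), read by FRET, with stated times of 30 s and 40 min; on this read-out higher numbers stand for weaker inhibition and lower numbers for stronger inhibition. Compound 1 gives 490 nM, the lower of the two numbers. Compound 2 gives 40100 nM, a much higher number, and the gap between the two lies well beyond the scatter. These two compounds differ from each other in more than one place, so their gap cannot be pinned on any single change.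

Compound 3 differs from compound 1 in one place: 2-acetylethyl in place of hydroxy on an aromatic carbon. Going by the values given here, no measured pair shows this exact change on its own, so its effect can only be estimated. Among the compounds with values here, the only compound without the hydroxy, compound 2, is far weaker, but it also differs elsewhere, so that comparison is only a loose hint. A moderate weakening is therefore expected. Compound 3 is estimated to give 1500 nM, with a likely range from 400 nM to 6000 nM. The expected step of a 3.1-fold higher number from compound 1 to compound 3 (0.49 log units; beyond the scatter) would lie somewhat beyond the scatter.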

Compound 3, half-maximal inhibitory concentration: 2490 nM
Compound 3: middle estimate off by 1.7-fold (0.22 log units), on the low side; low and high end bracket the measured number.
By their numbers in this assay, from the lowest: compound 1; then compound 3; then compound 2.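

In this assay, going by these compounds alone, replacing the hydroxy with 2-acetylethyl at this position gives a 5.1-fold higher number from compound 1 to compound 3 (0.71 log units; beyond the scatter), the first step here that can be pinned on a single change, and it is a modest one. The hydroxy is therefore not essential for inhibition in this series, since compound 3 still gives 2490 nM with a larger group that has no hydrogen-bond donor, so this position accepts a chain at a moderate cost. The swap removes the donor and adds the chain at the same time, so this one step cannot divide its effect between the two, and no independent measurement explains it.

The compounds shown leave open whether the carbonyl of the chain matters, a question that a plain butyl chain at this position could help answer by keeping a similar length without the ketone. They also leave open how much of the step comes from losing the hydroxy itself, which a methoxy group could test with little added size, and whether an amine or a carboxylic acid on the chain would move the number in either direction.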